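Moving fluoro from 4-fluorophenyl to 3-fluorophenyl

The source may hold more compounds than are shown below. What is called first, only, known or untested is meant among the compounds shown, and "the series" means these compounds.

Among the measured compounds shown here, in a functional assay on HepG2 cells (Homo sapiens) for cytotoxicity, read by MTT assay, with a stated time of 72 h (on this read-out higher numbers stand for weaker inhibition and lower numbers for stronger inhibition), compound 2 `COc1c(OCCCCN2CCN(C)CC2)cc(O)c2c(=O)cc(-c3ccc(F)cc3)oc12` gives 2810 nM and holds the higher of the two numbers so far, while compound 1 `COc1c(OCCCCN2CCN(C)CC2)cc(O)c2c(=O)cc(-c3ccc(C)cc3)oc12` gives 1000 nM as its value. For the measured compounds named here, the one measured step is a 2.8-fold higher number from compound 1 to compound 2 (0.45 log units; beyond the scatter) and it swapped methyl for fluoro rather than moving a group, so it offers a rough size but no direction. Compound 3 `COc1c(OCCCCN2CCN(C)CC2)cc(O)c2c(=O)cc(-c3cccc(F)c3)oc12` has 3-fluorophenyl in place of 4-fluorophenyl on an aromatic carbon and keeps the same atoms. The expected change is a 1.1-fold lower number from compound 2 to compound 3 (0.05 log units; within the scatter) and is estimated to stay within the scatter. Compound 3 is estimated at 2500 nM with an expected range from 1000 nM to 6500 nM around that figure.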

Compound 3, half-maximal inhibitory concentration: 2580 nM
Compound 3: the middle estimate sits 1.0-fold (0.01 log units) below what was measured; low and high end bracket the measured number.
By their numbers in this assay, from the lowest: compound 1; then compounds 3 and 2 (each within the scatter of the next).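

In this assay, moving the fluoro around the phenyl ring gives a 1.1-fold lower number from compound 2 to compound 3 (0.04 log units; within the scatter), so 3-fluorophenyl and 4-fluorophenyl cannot be told apart here. Set against 4-methylphenyl, the new isomer shows a 2.6-fold higher number from compound 1 to compound 3 (0.41 log units; beyond the scatter), so the gap seen with 4-fluorophenyl also holds with 3-fluorophenyl. Nothing available explains these numbers. Still open, from the compounds shown here alone, is how a chloro, methoxy or trifluoromethyl group on this ring would compare with fluoro and methyl. Going by these compounds, an amine or a carboxylic acid there is equally open.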